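The compounds below may be only part of what the source reports. "The series", "measured", "known", "first", "only" and "open" are said of these compounds alone.

Measured in an assay on HEK293 cells for displacement of a labelled ligand from 5-hydroxytryptamine receptor 7 (Homo sapiens), read by radioligand binding, with a stated time of 1 h; on this read-out higher numbers stand for weaker inhibition and lower numbers for stronger inhibition:
compound 1 `CN1CCN(c2nc(N)nc(COc3cccc(Cl)c3)n2)CC1`, 5820 nM
compound 2 `Cc1cccc(OCc2nc(N)nc(N3CCN(C)CC3)n2)c1`, 10700 nM
compound 3 `CC(Oc1cccc(Cl)c1)c1nc(N)nc(N2CCN(C)CC2)n1`, 8360 nM

Compound 3 holds the middle of the three numbers; all three sit within the scatter of one another, so no ranking among them can be read. Compound 4 `CC(Sc1ccccc1Cl)c1nc(N)nc(N2CCN(C)CC2)n1` is not yet measured. Relative to compound 3 the change is (2-chlorophenyl)sulfanyl in place of 3-chlorophenoxy on a saturated chain carbon bound to an aromatic carbon and a saturated chain carbon. The measured steps do not touch this swap: a 1.8-fold higher number from compound 1 to compound 2 (0.26 log units; within the scatter) and a 1.4-fold higher number from compound 1 to compound 3 (0.16 log units; within the scatter), both within the scatter and both on other parts of the molecule. Among the measured compounds shown here, the only guide is that every change tried so far has left this assay essentially unchanged, so for compound 4 no step beyond the scatter is expected, a 1.0-fold lower number from compound 3 to compound 4 (0.02 log units; within the scatter). Compound 4 is therefore estimated at 8000 nM, with a range of 2500 nM to 25000 nM.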

Compound 4, inhibition constant: 4570 nM
Compound 4: middle estimate off by 1.8-fold (0.24 log units), on the high side; the measured number falls inside the stated range.
By their numbers in this assay, from the lowest: compounds 4, 1, 3 and 2 (each within the scatter of the next, the first and the last beyond it).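

In this assay, (2-chlorophenyl)sulfanyl in place of 3-chlorophenoxy gives a 1.8-fold lower number from compound 3 to compound 4 (0.26 log units; within the scatter), so this position accepts a change of both the linking atom and the chlorine placement with no step beyond the scatter. The two changes arrive together, and this single step cannot divide its size between them. No available evidence bears on this result.

Open, from the compounds shown here alone, is how sulfur and oxygen compare with the chlorine placement held fixed. Also open, going by these compounds, is whether an amine or a carboxylic acid on the phenyl ring would give a step beyond the scatter.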